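Thiophene Stripped of Its Methyls: A Forecast for Compound 3

The source may report more compounds than this note shows. Statements on the series, on what has been measured and on what is new or still open speak of the compounds shown alone.

Compound 1, `Cc1cc(-c2nc3sc(C)cn3c2/C=N/NC(=N)N)c(C)s1`, gives 18200 nM in a functional assay on cells (Cancer cell lines, Homo sapiens) for inhibition; a higher number here means a weaker inhibitor of growth, a lower number a stronger inhibitor of growth.
Compound 2, `Cc1cn2c(/C=N/Nc3ccccn3)c(-c3ccc(Cl)c([N+](=O)[O-])c3)nc2s1`, gives 19500 nM in this assay.

Compound 1 holds the lower of the two numbers, but compound 2 sits so close to it that the gap lies within the scatter, so neither can be called the stronger inhibitor. Compound 3, `Cc1cn2c(/C=N/NC(=N)N)c(-c3ccsc3)nc2s1`, differs from compound 1 by thiophen-3-yl in place of 2,5-dimethylthiophen-3-yl on an aromatic carbon. For the measured compounds named here, no measured pair shows this change, so there is no step to lean on. The two measured compounds, both well out in weak territory, suggest that this core does not move far with changes of this kind, and the expected step from compound 1 to compound 3 is a 1.4-fold higher number from compound 1 to compound 3 (0.14 log units; within the scatter), a slight weakening or none beyond the scatter. Compound 3 is therefore expected to give about 25000 nM in this assay, somewhere between 8000 nM and 80000 nM.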

Compound 3, concentration for total growth inhibition: 19500 nM
The estimate for compound 3 lay 1.3-fold (0.11 log units) above the measured number, and the stated range covers the measured number.
By their numbers in this assay, from the lowest: compounds 1, 2 and 3 (each within the scatter of the next).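

In this assay, for the compounds shown here, thiophen-3-yl in place of 2,5-dimethylthiophen-3-yl on this aromatic carbon gives a 1.1-fold higher number from compound 1 to compound 3 (0.03 log units; within the scatter), the only step here that isolates a single change. Compounds 1 and 2 differ in more than one place, so they could not show this; the new pair shows that, on the shared core, going from 7 heavy atoms to 5 in this group leaves no difference that can be read beyond the scatter. No measurement at hand bears on the reason for this result.

The two methyl groups have been tested only together, so a thiophen-3-yl carrying a single methyl remains an open case. Also open, from the compounds shown here alone, is whether a different group on this carbon, such as a phenyl ring, an amine or a carboxylic acid, would give a number that departs from those of compound 1 and compound 3.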